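The compounds below may be only part of what the source reports. "The series", "measured", "known", "first", "only" and "open" are said of these compounds alone.

Measured in a functional assay with Oryctolagus cuniculus as the target; on this read-out higher numbers stand for weaker inhibition and lower numbers for stronger inhibition:
- compound 1 `COc1ccc(-c2nc(/N=C(\N)NC(C)C)sc2-c2ccc(OC)cc2)cc1`: > 100 nM, a limit
- compound 2 `COc1ccc(-c2nc(/N=C(\N)NC3CCCCC3)sc2-c2ccc(OC)cc2)cc1`: > 1000 nM, a limit
- compound 3 `C/N=C(/NC)Nc1nc(-c2ccc(OC)cc2)c(-c2ccc(OC)cc2)s1`: 970 nM

Going by the values given here, compound 3 holds the only true number in this set, since the other two results are limits. Compound 4 `COc1ccc(-c2nc(CNC(C)=O)sc2-c2ccc(OC)cc2)cc1` differs from compound 3 in a single place: a group of 5 heavy atoms (3 carbon, 1 nitrogen, 1 oxygen; no ring) in place of a group of 6 heavy atoms (3 carbon, 3 nitrogen; no ring), on an aromatic carbon.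

The measured steps offer little guidance. There is a step that the two limits leave unreadable from compound 1 to compound 2, and there is a step that the limit leaves unreadable from compound 1 to compound 3. The remaining one is an at least 1.0-fold lower number from compound 2 to compound 3 (0.01 log units; that floor lies within the scatter). All three exchange one nitrogen-rich group for another, and none brings in the acetamidomethyl group. No direction can therefore be read from them, and no step beyond the scatter is expected in this assay. Among the compounds with values here, the expectation stays anchored on compound 3 at 970 nM, with a wide margin because the change has no measured precedent. For compound 4 the expected value is 900 nM, with an estimated range of 150 nM to 5000 nM. This estimate amounts to a 1.1-fold lower number from compound 3 to compound 4 (0.03 log units; within the scatter).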

Compound 4, half-maximal inhibitory concentration: 15 nM
Compound 4: the middle estimate sits 60-fold (1.78 log units) above what was measured, and the stated range ends above it.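

In this assay, going by these compounds alone, the aromatic carbon next to the ring nitrogen and the ring sulfur proves highly sensitive to the group it carries: acetamidomethyl in place of the nitrogen-rich group gives a 65-fold lower number from compound 3 to compound 4 (1.81 log units; beyond the scatter) and thus the first readable step beyond the scatter. The same exchange also clears the two compounds that stand at limits, with an at least 66-fold lower number from compound 2 to compound 4 (1.82 log units; beyond the scatter) and an at least 6.6-fold lower number from compound 1 to compound 4 (0.82 log units; beyond the scatter) as floors rather than exact sizes, so the gain holds against all three nitrogen-rich groups. Nothing shown here accounts for this gain.

As far as these compounds go, how an aminomethyl group, a carboxylic acid or a longer amide chain would read at this position remains open. So does the question of whether the carbonyl or the amide hydrogen of acetamidomethyl is needed for the result.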